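Swapping the aryl group on the saturated ring carbon

A few compounds are considered here, and "the series" means these few. Any claim that something is new, unique, unknown or untested is made for them only; others in the source may bear on it.

Compound 1 `CC(C)=CCOc1ccc2c(c1)OC(c1cccc(F)c1)CC2=O` gives 4280 nM in a functional assay; a higher number here means a weaker inhibitor, a lower number a stronger inhibitor.
Compound 2 `CC(C)=CCOc1ccc2c(c1)OC(c1ccc(C)cc1C)CC2=O` gives 8260 nM in this assay.
Compound 3 `CC(C)=CCOc1cc(O)c2c(c1)OC(c1cccc(F)c1)CC2=O` gives 7240 nM in this assay.

Among these three numbers compound 3 stands second highest; compound 2 lies nearest to it and compound 1 furthest, but both gaps fall within the scatter, so no order among the three can be read from them. Compound 4 `CC(C)=CCOc1cc(O)c2c(c1)OC(c1ccc(C)cc1)CC2=O` differs from compound 3 in a single place: 4-methylphenyl in place of 3-fluorophenyl on a saturated ring carbon. Among the measured compounds shown here, two measured steps bear on this change. For the measured compounds named here, the only exchange of the aryl group on the saturated ring carbon seen so far is a 1.9-fold higher number from compound 1 to compound 2 (0.29 log units; within the scatter), where a 2,4-dimethylphenyl group entered in place of 3-fluorophenyl, and the number did not move beyond the scatter. The hydroxy on the aromatic carbon, which compound 3 and compound 4 share, was introduced in a 1.7-fold higher number from compound 1 to compound 3 (0.23 log units; within the scatter), again within the scatter. Going by the values given here, no measured pair covers the difference between 2,4-dimethylphenyl and 4-methylphenyl. The step is therefore expected to be small, perhaps a slight rise in the number, amounting to a 1.2-fold higher number from compound 3 to compound 4 (0.09 log units; within the scatter). Compound 4 is expected to give about 9000 nM in this assay, within a range from 4000 nM to 20000 nM.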

Compound 4, half-maximal inhibitory concentration: 4360 nM
Compound 4: the middle estimate sits 2.1-fold (0.31 log units) above what was measured, and the stated range covers the measured number.
By their numbers in this assay, from the lowest: compounds 1, 4, 3 and 2 (each within the scatter of the next).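

With a 1.7-fold lower number from compound 3 to compound 4 (0.22 log units; within the scatter), the exchange of 3-fluorophenyl for 4-methylphenyl on the saturated ring carbon, next to the ring oxygen, stays within the scatter in this assay. This is the first aryl exchange at this place on a core that carries the hydroxy, and, like a 1.9-fold higher number from compound 1 to compound 2 (0.29 log units; within the scatter) on the core without it, it gives no readable difference, so the two exchanges shown offer no basis for ranking these aryl groups. The fluorine of compound 3 and the methyl of compound 4 also sit in differently named positions of the phenyl ring, yet no effect of either the substituent or its placement can be separated from the scatter, and no available evidence bears on this result.

The compounds shown cover only phenyl rings bearing fluorine or methyl at this carbon, all of which give numbers within the scatter of their neighbours, so it remains open whether a phenyl ring carrying an amine or a carboxylic acid would shift the number beyond the scatter. From the compounds shown here alone, a saturated cyclohexyl ring or a pyridine ring in the same place is equally open.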